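Three analogues tolerated in HT-29 cells, and a fourth

The source may report more compounds than this note shows. Statements on the series, on what has been measured and on what is new or still open speak of the compounds shown alone.

Compound 1, `CN1C(=S)[C@@H](NC(=O)c2n[nH]c(Cc3ccccc3)n2)COc2ccccc21`: in a toxicity assay on HT-29 cells (Homo sapiens) for cytotoxicity (a higher number here means that more compound is tolerated, a lower number that less compound is tolerated), compound 1 gives > 50000 nM, a limit of the assay.
Compound 2, `CN1C(=S)[C@@H](NC(=O)c2nc(Cc3ccccc3)n(C)n2)COc2ccccc21`: in this assay compound 2 gives > 100000 nM, a limit of the assay.
Compound 3, `CCCn1nc(C(=O)N[C@H]2COc3ccccc3N(C)C2=S)nc1Cc1ccccc1`: in this assay compound 3 gives > 100000 nM, a limit of the assay.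

Compound 2 stands at the higher of the two limits that appear here, where two of the three values sit (the limit of > 100000 nM in this assay, at which 2 of the 3 values shown sit); the third value sits at the lower limit (the limit of > 50000 nM in this assay, at which 1 of the 3 values shown sits). Within the data shown here, none of the measured steps can be read: a step that the two limits leave unreadable from compound 1 to compound 2, a step that the two limits leave unreadable from compound 1 to compound 3 and a step that the two limits leave unreadable from compound 2 to compound 3 all run between limits and give no size and no direction.

Compound 4, `CN1C(=S)[C@@H](NC(=O)c2nc(Cc3ccccc3)n(CCCC#N)n2)COc2ccccc21`, differs from compound 2 by 2-cyanoethyl in place of hydrogen on a saturated chain carbon bound to an aromatic nitrogen. The nearest measured change, a step that the two limits leave unreadable from compound 2 to compound 3, also adds a chain on that carbon and leaves no readable shift. No step beyond the scatter is therefore expected in this assay, and compound 4 is expected to sit again at a limit. The estimate for compound 4 is 150000 nM, between 50000 nM and 500000 nM, which means an expected step that the limit leaves unreadable from compound 2 to compound 4.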

Compound 4, half-maximal cytotoxic concentration: > 100000 nM
Compound 4 was reported as a limit; the forecaster's own chance of this, stated with the estimate: 85%; the middle value does not contradict the limit.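

In this assay compound 4 gives > 100000 nM, a limit of the assay. Its steps from compound 1, compound 2 and compound 3 cannot be read, in size or in direction. The compounds shown leave open what concentration of any of them is cytotoxic, and whether the group on the aromatic nitrogen changes that concentration at all.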